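A few compounds are considered here, and "the series" means these few. Any claim that something is new, unique, unknown or untested is made for them only; others in the source may bear on it.

Measured so far, in a functional assay on MT4 cells (Homo sapiens) for cytotoxicity; on this read-out higher numbers stand for lower toxicity in this test and lower numbers for higher toxicity in this test:

Compound 1 `CC(C)Sc1nc(Cc2c(F)cccc2F)cc(=O)[nH]1` gives > 200000 nM, which is a limit of the assay and not a number.
Compound 2 `O=c1cc(Cc2c(F)cccc2F)nc(SC2CCCC2)[nH]1` gives > 200000 nM, also a limit of the assay rather than a number.
Among the measured compounds shown here, compound 3 `CC(C)Sc1nc(O)cc(C(C)c2c(Cl)cccc2Cl)n1` gives 117000 nM, the only plain number among the three.

Compound 1 and compound 2 differ by cyclopentyl in place of isopropyl on a sulfur. The step that the two limits leave unreadable from compound 1 to compound 2 cannot be read, because the limit of > 200000 nM in this assay, at which 2 of the 3 values shown sit, hides any shift. How the core of compound 3 differs from the core of compound 1 is not broken down here.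

Compound 4 `CC(c1cc(O)nc(SC2CCCC2)n1)c1c(Cl)cccc1Cl` differs from compound 3 by cyclopentyl in place of isopropyl on a sulfur, the same change as between compound 1 and compound 2. Since that earlier pair shows no readable movement, the step of a 1.0-fold higher number from compound 3 to compound 4 (0.01 log units; within the scatter) is expected to be small. Compound 4 is therefore estimated at 120000 nM, between 45000 nM and 250000 nM.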

Compound 4, half-maximal cytotoxic concentration: 78300 nM
Beside the measured number, compound 4's estimate is 1.5-fold (0.19 log units) above it; the measured number falls inside the stated range.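

In this assay, cyclopentyl in place of isopropyl on the sulfur gives a 1.5-fold lower number from compound 3 to compound 4 (0.17 log units; within the scatter), so on this core the change stays within the usual scatter. On the core of compound 1 the same change cannot be read, because compound 1 and compound 2 both stand at a limit of the assay and not at a number: the limit of > 200000 nM in this assay, at which 2 of the 4 values shown sit. The series therefore offers one readable pair, which shows nothing about whether the result carries from one core to the other.

Going by these compounds, what stays open is how this read-out would respond to a longer chain or a phenyl group on the sulfur. On these data alone, an amine or a carboxylic acid there is equally open.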